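Swapping the ester for a dimethoxyphenyl on the coumarin-linked dithiolane

The source may report more compounds than this note shows. Statements on the series, on what has been measured and on what is new or still open speak of the compounds shown alone.

Two compounds share a long chain ending in a cyclic disulfide amide. Compound 1 `Cc1cc(=O)oc2cc(OCCCCCn3cc(CNC(=O)CCCCC4CCSS4)nn3)ccc12` gives 66.3% in a functional assay on PC-12 cells (Rattus norvegicus) for cytotoxicity, read by MTT assay, with stated times of 3 h and 2 h, tested at 10 uM; a higher number here means a stronger effect of the compound at the concentration tested, a lower number a weaker effect. Compound 2 `CCOC(=O)c1cc2ccc(OCCCCCn3cc(CNC(=O)CCCCC4CCSS4)nn3)cc2oc1=O` gives 38.3% in this assay, the lower of the two, and its gap to compound 1 lies beyond the scatter. Compound 3 `COc1ccc(-c2cc3ccc(OCCCCCn4cc(CNC(=O)CCCCC5CCSS5)nn4)cc3oc2=O)cc1OC` carries 3,4-dimethoxyphenyl in place of ethoxycarbonyl on an aromatic carbon. Among the measured compounds shown here, no step between measured compounds tells how this change acts, so a modest step, direction uncertain, is expected from compound 2 to compound 3 in this assay, namely a number 9.7 percentage points higher from compound 2 to compound 3 (within the scatter). Compound 3 is therefore estimated at 48%, within 28% to 68%.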

Compound 3, a percentage reported as activity, at one concentration (the size of the read-out at that concentration, not a potency): 50.5%
For compound 3 the middle estimate is 2.5 percentage points below the measured one; the measured number falls inside the stated range.
By their numbers in this assay, from the lowest: compound 2; then compound 3; then compound 1.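

In this assay, placing 3,4-dimethoxyphenyl in place of ethoxycarbonyl on this aromatic carbon gives a number 12.2 percentage points higher from compound 2 to compound 3 (beyond the scatter) and so shows that the number responds to the group held here. The entering group adds a six-membered aromatic ring and more heavy atoms, while the count of hydrogen-bond acceptors stays the same. Nothing measured here explains the step. As far as these compounds go, whether the ring or its two methoxy groups carry the step stays open, and a plain phenyl would help to separate them. From the compounds shown here alone, how an amine or a carboxylic acid on this carbon would read also stays open.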